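Adding a Third Benzyloxy Group to a Shared Core

The compounds below may be only part of what the source reports. "The series", "measured", "known", "first", "only" and "open" are said of these compounds alone.

Three related compounds have been tested in a functional assay on MDA-MB-231 cells (Homo sapiens) for cytotoxicity, read by MTT assay, with a stated time of 24 h; a higher number here means a weaker inhibitor, a lower number a stronger inhibitor. Compound 1 `Cc1cc(O)c(C(=O)/C=C/c2ccccc2)c(-c2ccccc2)c1C(=O)/C=C/c1ccccc1` gives 8500 nM, compound 2 `Cc1cc(O)c(C(=O)/C=C/c2ccc(OCc3ccccc3)cc2)c(-c2ccccc2)c1C(=O)/C=C/c1ccc(OCc2ccccc2)cc1` gives 10000 nM, and compound 3 `Cc1cc(O)c(C(=O)/C=C/c2ccc(Cl)cc2)c(-c2ccc(Br)cc2)c1C(=O)/C=C/c1ccc(Cl)cc1` gives 15000 nM. Compound 2 stands among these three with its gaps to compound 1 and to compound 3 both inside the usual scatter, so the three cannot be told apart on these numbers. Compound 4 `Cc1cc(O)c(C(=O)/C=C/c2ccc(OCc3ccccc3)cc2)c(-c2ccc(OCc3ccccc3)cc2)c1C(=O)/C=C/c1ccc(OCc2ccccc2)cc1` is the next candidate; it differs from compound 2 by benzyloxy in place of hydrogen on an aromatic carbon. Among the measured compounds shown here, no measured pair isolates this change, so nothing here points to a step in either direction beyond the scatter, and a flat outcome is the working expectation. Compound 4 is expected to give about 12000 nM in this assay, with a likely range from 5000 nM to 30000 nM, an expected step of a 1.2-fold higher number from compound 2 to compound 4 (0.08 log units; within the scatter).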

Compound 4, half-maximal inhibitory concentration: 20000 nM
Beside the measured number, compound 4's estimate is 1.7-fold (0.22 log units) below it, and the stated range covers the measured number.
By their numbers in this assay, from the lowest: compounds 1, 2, 3 and 4 (each within the scatter of the next, the first and the last beyond it).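

Benzyloxy in place of hydrogen on an aromatic carbon, para to a large group, gives a 2.0-fold higher number from compound 2 to compound 4 (0.30 log units; within the scatter) in this assay and is the first direct reading of this change among these compounds. This single pair shows that a group with its own six-membered aromatic ring can stand at this position without a step beyond the scatter. No measurement shown here speaks to why the numbers fall as they do. As far as these compounds go, whether an amine or a carboxylic acid at this position would give a step beyond the scatter remains open.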